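A few compounds are considered here, and "the series" means these few. Any claim that something is new, unique, unknown or untested is made for them only; others in the source may bear on it.

Measured so far:
compound 1, `Nc1scc(CN2CCN(c3ccc([N+](=O)[O-])cc3)CC2)c1C(=O)c1ccc(Cl)cc1`: -13%
compound 2, `Nc1scc(CN2CCN(c3cccc4ccccc34)CC2)c1C(=O)c1ccc(Cl)cc1`: 0%

In a functional assay on CHO cells with adenosine receptor A1 (Homo sapiens) as the target, read by cAMP accumulation and immunoassay, with a stated time of 6 min, tested at 0.1 uM (on this read-out lower numbers stand for a stronger effect and higher numbers for a weaker effect at the one concentration tested), compound 1 gives -13%, and compound 2 gives 0%. Within the data shown here, compound 2 thus stands highest of the two numbers at hand; its nearest neighbour is compound 1, and the one step that separates them is a number 13 percentage points higher from compound 1 to compound 2 (beyond the scatter), which came with naphthalen-1-yl in place of 4-nitrophenyl on an amine nitrogen in a ring.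

Compound 3, `Nc1scc(CN2CCN(c3cc(F)cc(F)c3)CC2)c1C(=O)c1ccc(Cl)cc1`, has not yet been measured in this assay. It differs from compound 2 in one place: 3,5-difluorophenyl in place of naphthalen-1-yl on an amine nitrogen in a ring. Among the measured compounds shown here, the only measured step that concerns the same position is a number 13 percentage points higher from compound 1 to compound 2 (beyond the scatter); it shows that exchanging one group for another on that nitrogen moved the read-out by a modest amount in the single case available, and nothing is known of 3,5-difluorophenyl there. Both measured values lie close to no effect, so the step from compound 2 to compound 3 is estimated as a number 5 percentage points lower from compound 2 to compound 3 (within the scatter), within the scatter. Compound 3 is therefore expected to give about -5% in this assay, with a range from -20% to 12%.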

Compound 3, a percentage reported as activity, at one concentration (the size of the read-out at that concentration, not a potency): -5%
For compound 3 middle estimate and measured number coincide at the digits printed; the range from low to high includes it.
By their numbers in this assay, from the lowest: compounds 1, 3 and 2 (each within the scatter of the next, the first and the last beyond it).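

In this assay, 3,5-difluorophenyl on the amine nitrogen in a ring cannot be told apart from naphthalen-1-yl (a number 5 percentage points lower from compound 2 to compound 3 (within the scatter)), nor from 4-nitrophenyl (a number 8 percentage points higher from compound 1 to compound 3 (within the scatter)). The change from naphthalen-1-yl to 3,5-difluorophenyl replaces two six-membered aromatic rings of carbon only with one and 10 heavy atoms with 8, yet this difference in the group leaves the read-out within the scatter. Compound 3 also fills the gap between the two earlier compounds: the one difference beyond the scatter, a number 13 percentage points higher from compound 1 to compound 2 (beyond the scatter), now has a compound within the scatter of each end, so the three aryl groups form a single narrow run of numbers rather than two separate levels.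

Nothing at hand explains why these three groups read so much alike. As far as these compounds go, it remains open whether a non-aromatic group on that nitrogen, such as cyclohexyl or a short alkyl chain, or a phenyl ring bearing a carboxylic acid or an amine, would take the read-out outside this narrow run, and whether any such result would hold at other concentrations.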